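The source may hold more compounds than are shown below. What is called first, only, known or untested is meant among the compounds shown, and "the series" means these compounds.

Compound 1 `CCC1(Cc2ccccc2)OS(=O)(=O)C=C1OCC(=O)OC` was examined in an ADME assay on HEL cells (Homo sapiens) for cytotoxicity, with a stated time of 3 days; on this read-out lower numbers stand for higher toxicity in this test and higher numbers for lower toxicity in this test. In this assay compound 1 gives only a limit, > 200000 nM. Two companions share its core. Compound 2 `CCC1(Cc2ccccc2)OS(=O)(=O)C=C1OCc1ccc(Cl)cc1` carries 4-chlorophenyl on a saturated chain carbon bound to an oxygen on an unsaturated carbon; in this assay compound 2 likewise reaches only the limit, > 200000 nM. Compound 3 `CCC1(Cc2ccccc2)OS(=O)(=O)C=C1OC(=O)c1ccccc1` bears benzoyl on an oxygen on an unsaturated carbon, and in this assay compound 3 again stops at the limit, > 200000 nM. All three values sit at the limit of > 200000 nM in this assay, at which 3 of the 3 values shown sit, so the steps a step that the two limits leave unreadable from compound 1 to compound 2, a step that the two limits leave unreadable from compound 1 to compound 3 and a step that the two limits leave unreadable from compound 2 to compound 3 cannot be read in size or direction.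

Compound 4 `CCC1(Cc2ccccc2)OS(=O)(=O)C=C1OCc1ccc(F)cc1` differs from compound 1 by 4-fluorophenyl in place of methoxycarbonyl on a saturated chain carbon bound to an oxygen on an unsaturated carbon. The nearest measured change, a step that the two limits leave unreadable from compound 1 to compound 2, gave nothing readable, and the other two steps are equally silent, so no direction can be drawn from them. Compound 4 is therefore expected to give 200000 nM in this assay, between 100000 nM and 400000 nM. That estimate means an expected step of a number no higher from compound 1 to compound 4 (the limit leaves the size open), with another limit the most likely outcome.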

Compound 4, half-maximal cytotoxic concentration: > 50000 nM
Compound 4: no number, only a limit (the forecaster's own chance of this, stated with the estimate: 85%); the middle value is on the limit's open side.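

In this assay compound 4 gives only a limit, > 50000 nM. Its steps from compound 1, compound 2 and compound 3 cannot be read in size or direction. The compounds shown leave open whether any of these changes on the shared core alters the half-maximal cytotoxic concentration at all.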